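The source may report more compounds than this note shows. Statements on the series, on what has been measured and on what is new or still open speak of the compounds shown alone.

Measured compounds and their values in an assay on CHO cells for antagonist activity at transient receptor potential cation channel subfamily V member 1 (Homo sapiens), read by FLIPR and calcium flux; on this read-out lower numbers stand for stronger inhibition and higher numbers for weaker inhibition:
Compound 1, `CC(C(=O)NCc1ccc(C(F)(F)F)nc1Br)c1ccc(NS(C)(=O)=O)c(F)c1`: 169 nM
Compound 2, `CCCCCCc1nc(C(F)(F)F)ccc1CNC(=O)C(C)c1ccc(NS(C)(=O)=O)c(F)c1`: 1.6 nM
Compound 3, `CC(C(=O)NCc1ccc(C(F)(F)F)nc1C1CC2CCC1C2)c1ccc(NS(C)(=O)=O)c(F)c1`: 1.5 nM

Among these three, compound 3 gives the lowest number, though its gap to compound 2 lies within the usual scatter, so the two cannot be ranked against each other; only compound 1 stands clearly apart, with a far higher number.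

Compound 4, `CC(C(=O)NCc1ccc(C(F)(F)F)nc1C1=CCCCC1)c1ccc(NS(C)(=O)=O)c(F)c1`, has not been measured. It differs from compound 3 in one place: a group of 6 heavy atoms (6 carbon; one six-membered non-aromatic ring of carbon only) in place of a group of 7 heavy atoms (7 carbon; 2 five-membered non-aromatic rings of carbon only), on an aromatic carbon. The new group sits on an aromatic carbon of a six-membered aromatic ring with one nitrogen, next to the ring nitrogen.

Two measured steps show what happens at this position. Replacing bromo there with a six-carbon chain gave a 110-fold lower number from compound 1 to compound 2 (2.02 log units; beyond the scatter), and replacing it with the two-ring carbon group gave a 110-fold lower number from compound 1 to compound 3 (2.05 log units; beyond the scatter). Between those two carbon groups the change was a 1.1-fold lower number from compound 2 to compound 3 (0.03 log units; within the scatter). So far, any sizeable carbon group at this position has given a similar low number, and the exact shape of that group has not mattered beyond the scatter. A six-membered ring with one double bond is another group of that kind. Compound 4 is therefore expected to show a step of a 1.3-fold higher number from compound 3 to compound 4 (0.12 log units; within the scatter) in this assay, not beyond the scatter. The estimate for compound 4 is 2 nM, with a range from 0.7 nM to 6 nM.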

Compound 4, inhibition constant: 0.7 nM
The estimate for compound 4 lay 2.9-fold (0.46 log units) above the measured number; measured number inside the range.
By their numbers in this assay, from the lowest: compound 4; then compounds 3 and 2 (each within the scatter of the next); then compound 1.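

In this assay, going by these compounds alone, the cyclohex-1-en-1-yl group is the first carbon group at this position to stand apart from the others: replacing the two-ring group with it gave a 2.1-fold lower number from compound 3 to compound 4 (0.33 log units; beyond the scatter), and replacing hexyl with it gave a 2.3-fold lower number from compound 2 to compound 4 (0.36 log units; beyond the scatter). Within the data shown here, the earlier pair of carbon groups could not be told apart, so this is the first sign that the choice of carbon group can change the number here, although both steps are modest beside the large gain over bromo, a 240-fold lower number from compound 1 to compound 4 (2.38 log units; beyond the scatter). Nothing available here explains why this ring gives the lower number.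

A cyclohexyl group, the same ring without the double bond, would show whether the double bond counts, while a phenyl ring would show how a flat aromatic group compares at this position. As far as these compounds go, it also remains open whether a ring holding nitrogen or oxygen, such as piperidine or morpholine, would keep numbers as low as those of the carbon groups.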